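The source may report more compounds than this note shows. Statements on the series, on what has been measured and on what is new or still open speak of the compounds shown alone.

Compound 1 `CN(C)C(=O)c1nc([C@@H](O)[C@H](O)[C@H](O)CO)c[nH]1` gives 11.3 mL/min/kg
Compound 2 `OC[C@@H](O)[C@@H](O)[C@H](O)c1c[nH]c(-c2cocn2)n1` gives 16.6 mL/min/kg

In an in vivo ADME assay on the whole organism (strain 129/SvEvBrd x C57BL/6) for pharmacokinetics, with Mus musculus as the target, at a dose of 1 mg/kg by the intravenous route (on this read-out lower numbers stand for slow clearance and higher numbers for fast clearance), compound 2, at 16.6 mL/min/kg, lies within the scatter of compound 1. Compound 3 `OC[C@@H](O)[C@@H](O)[C@H](O)c1c[nH]c(-c2ncccn2)n1` has pyrimidin-2-yl in place of 1,3-oxazol-4-yl on an aromatic carbon. For the measured compounds named here, the one measured step at this place is a 1.5-fold higher number from compound 1 to compound 2 (0.17 log units; within the scatter). Going by the values given here, no compound with pyrimidin-2-yl has been measured yet. On this evidence, no step beyond the scatter is expected in this assay. The estimated step is a 1.1-fold lower number from compound 2 to compound 3 (0.04 log units; within the scatter). Compound 3 is expected at 15 mL/min/kg, with an estimated range of 8 mL/min/kg to 28 mL/min/kg.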

Compound 3, clearance: 15.2 mL/min/kg
Compound 3: middle estimate off by 1.0-fold (0.01 log units), on the low side, and the stated range covers the measured number.
By their numbers in this assay, from the lowest: compounds 1, 3 and 2 (each within the scatter of the next).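

In this assay, a six-membered aromatic ring at this position reads no differently from a five-membered one: the change to pyrimidin-2-yl gives a 1.1-fold lower number from compound 2 to compound 3 (0.04 log units; within the scatter), and the clearance stays in the same range. Measured against dimethylcarbamoyl, pyrimidin-2-yl gives a 1.3-fold higher number from compound 1 to compound 3 (0.13 log units; within the scatter), so none of the three groups on this aromatic carbon separates from the others. Nothing available explains this result. Going by these compounds, it remains open whether an amine, a carboxylic acid or a longer chain here would shift clearance beyond the scatter, and what changing the group of 8 heavy atoms would do.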